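Three Sulfonamides at the Limit, a Fourth Awaited

The compounds below may be only part of what the source reports. "The series", "measured", "known", "first", "only" and "open" are said of these compounds alone.

Measured so far:
compound 1 `O=S(=O)(Nc1ccc(-c2nc3ccccc3o2)cc1)c1ccc(Cl)c(C(F)(F)F)c1`: > 63000 nM
compound 2 `O=S(=O)(Nc1ccc(-c2nc3ccccc3o2)cc1)c1ccccc1Cl`: > 63000 nM
compound 3 `O=S(=O)(Nc1ccc2oc(-c3ccccc3)nc2c1)c1cccc(F)c1`: > 63000 nM

The numbers come from an assay on isolated protein for inhibition of malate dehydrogenase, mitochondrial (Sus scrofa), with stated times of 45 min and 30 min; a lower number here means a stronger inhibitor, a higher number a weaker inhibitor. In this assay compound 1 gives > 63000 nM, which is a limit of the assay and not a number. Compound 2 gives > 63000 nM in this assay, again a limit. Compound 3 gives > 63000 nM in this assay, once more a limit. So compound 3 stands nowhere in particular among the measured compounds: all three sit at the limit of > 63000 nM in this assay, at which 3 of the 3 values shown sit, and no one of them can be placed above or below another.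

Compound 4 `CCc1ccc(S(=O)(=O)Nc2ccc3oc(-c4ccccc4)nc3c2)cc1` shares its core with compound 3 and differs in one place: 4-ethylphenyl in place of 3-fluorophenyl on a sulfonyl sulfur. For the measured compounds named here, no measured step between two compounds tells how this assay answers a change of this kind, so the expected size of the step in this assay has no anchor. Given that compound 3 sits at the limit, the expectation for compound 4 is that this assay most likely again returns a limit, with no step beyond the scatter expected as a number no higher from compound 3 to compound 4 (the limit leaves the size open). Compound 4 is therefore estimated at 63000 nM, within 20000 nM to 200000 nM.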

Compound 4, half-maximal inhibitory concentration: > 63000 nM
Compound 4: no number, only a limit; the forecaster's own chance of this, stated with the estimate: 75%; the middle value lies on the limit itself.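

In this assay compound 4 gives > 63000 nM, which is a limit of the assay and not a number. Compound 3 also stands at a limit, so the step between them cannot be read. The compounds shown leave open how far any of them is from a measurable inhibition in this assay, since all share one limit: the limit of > 63000 nM in this assay, at which 4 of the 4 values shown sit.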